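Cytotoxicity of a Small Amide Series in Vero Cells

The compounds below may be only part of what the source reports. "The series", "measured", "known", "first", "only" and "open" are said of these compounds alone.

- Compound 1 `COc1ccc(NC(=O)c2cc(N(C)Cc3ccccc3)ncn2)cc1`: 287000 nM
- Compound 2 `CN(CC1CCCCC1)c1cc(C(=O)Nc2ccccc2)ncn1`: 178000 nM
- Compound 3 `O=C(Nc1ccccc1)c1cc(OCc2ccccc2)ncn1`: "not determined" (no result reported)

Among the measured compounds shown here, in an ADME assay on Vero cells (Chlorocebus sabaeus) for cytotoxicity, read by MTT assay (a lower number here means a stronger inhibitor, a higher number a weaker inhibitor), only two numbers are available. Compound 2 gives 178000 nM, which lies within the usual scatter of compound 1 at 287000 nM.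

Compound 4 `CN(Cc1ccc(Cl)cc1)c1cc(C(=O)Nc2ccccc2)ncn1` has 4-chlorophenyl in place of cyclohexyl on a saturated chain carbon bound to a nitrogen on an aromatic ring. For the measured compounds named here, no measured step shows this change, so no shift beyond the scatter is expected. The expected 1.2-fold lower number from compound 2 to compound 4 (0.07 log units; within the scatter) is therefore small. For compound 4 the estimated value is 150000 nM, with an expected range of 70000 nM to 300000 nM.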

Compound 4, half-maximal inhibitory concentration: 207000 nM
Compound 4: the middle estimate sits 1.4-fold (0.14 log units) below what was measured; the measured number falls inside the stated range.
By their numbers in this assay, from the lowest: compounds 2, 4 and 1 (each within the scatter of the next).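

The first step read at this position, on a saturated chain carbon bound to a nitrogen on an aromatic ring, gives in this assay a 1.2-fold higher number from compound 2 to compound 4 (0.07 log units; within the scatter). Thus 4-chlorophenyl, an aromatic ring bearing chlorine, and cyclohexyl, a non-aromatic ring of carbon only, give values within the scatter of each other at this place. Nothing available here accounts for this result. The compounds shown leave open whether a ring carrying an amine or a carboxylic acid, or a longer chain at this place, would give a step beyond the scatter.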